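The source may report more compounds than this note shows. Statements on the series, on what has been measured and on what is new or still open speak of the compounds shown alone.

In a toxicity assay on PC-12 cells (Rattus norvegicus) for cytotoxicity, read by MTT assay (a higher number here means a weaker inhibitor, a lower number a stronger inhibitor), three compounds have been measured:

Compound 1 `Cc1ccc(-n2nc(-c3ccc(C(F)(F)F)cc3O)nc2-c2ccccc2O)cc1`: 113000 nM
Compound 2 `Oc1cc(C(F)(F)F)ccc1-c1nc(-c2ccccc2O)n(-c2ccc(Br)cc2)n1`: 66800 nM
Compound 3 `Oc1cc(C(F)(F)F)ccc1-c1nc(-c2ccccc2O)n(-c2cccc(C(F)(F)F)c2)n1`: 49700 nM

Compound 3 lies at the low end of this short series. The change from compound 1 is a 2.3-fold lower number from compound 1 to compound 3 (0.36 log units; beyond the scatter), while the change from compound 2 is a 1.3-fold lower number from compound 2 to compound 3 (0.13 log units; within the scatter). Compound 4 `COc1cccc(-n2nc(-c3ccc(C(F)(F)F)cc3O)nc2-c2ccccc2O)c1` follows from compound 3 by one change: methoxy in place of trifluoromethyl on an aromatic carbon. This places methoxy in place of trifluoromethyl on an aromatic carbon.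

Within the data shown here, no measured step makes exactly this swap, but all three alter the same aryl group, and all are small. Besides the two above, there is a 1.7-fold lower number from compound 1 to compound 2 (0.23 log units; within the scatter). With compound 3 at the low end, a small rise is more likely than a further fall, though it may not clear the scatter. The step expected is a 1.6-fold higher number from compound 3 to compound 4 (0.21 log units; within the scatter). Compound 4 is estimated at 80000 nM, with an expected range from 40000 nM to 150000 nM.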

Compound 4, half-maximal inhibitory concentration: 56400 nM
Compound 4: middle estimate off by 1.4-fold (0.15 log units), on the high side, within the range that was stated.
By their numbers in this assay, from the lowest: compounds 3, 4, 2 and 1 (each within the scatter of the next, the first and the last beyond it).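

In this assay, replacing trifluoromethyl with methoxy on this aromatic carbon, meta to a large group, gives a 1.1-fold higher number from compound 3 to compound 4 (0.05 log units; within the scatter), so a change from a group of four heavy atoms with no hydrogen-bond acceptor to one of two heavy atoms with one acceptor leaves the reading within the scatter. The 3-methoxyphenyl group likewise stays within the scatter of the two para-free comparison groups' compounds, with a 1.2-fold lower number from compound 2 to compound 4 (0.07 log units; within the scatter) and a 2.0-fold lower number from compound 1 to compound 4 (0.30 log units; within the scatter), the last differing from the step to the 3-(trifluoromethyl)phenyl compound, which is printed as beyond the scatter. Nothing available bears on why these two groups read so alike.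

The compounds shown leave open whether an amine or a carboxylic acid on this same aromatic carbon would move the number beyond the scatter. They also leave open whether a longer chain there, such as an ethoxy group, would read any differently from methoxy.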